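A few compounds are considered here, and "the series" means these few. Any claim that something is new, unique, unknown or untested is made for them only; others in the source may bear on it.

In a functional assay on HepG2 cells (Homo sapiens) for antiproliferative activity, read by MTT assay, with a stated time of 48 h (a higher number here means a weaker inhibitor, a lower number a stronger inhibitor), compound 1 `COc1ccc(/C=C/c2cc(OC)cc(OC)c2/C=C/C(=O)c2ccc(Cl)c(Cl)c2)cc1` gives 10.8 ug/mL, compound 2 `COc1ccc(/C=C/c2cc(OC)cc(OC)c2/C=C/C(=O)c2cccc(OC)c2)cc1` gives 11.6 ug/mL, and compound 3 `COc1ccc(/C=C/c2cc(OC)cc(OC)c2/C=C/C(=O)c2ccc(C)cc2)cc1` gives 4.8 ug/mL. Compound 1 thus shares the higher pair of numbers with compound 2, while compound 3 lies lower. Compound 4 `CCCCOc1ccc(C(=O)/C=C/c2c(/C=C/c3ccc(OC)cc3)cc(OC)cc2OC)cc1` keeps the core of compound 1 and alters only the group on the carbonyl carbon: 4-butoxyphenyl in place of 3,4-dichlorophenyl on a carbonyl carbon. Three measured exchanges at that carbonyl carbon bear on this change. One gives a 1.1-fold higher number from compound 1 to compound 2 (0.03 log units; within the scatter), another gives a 2.3-fold lower number from compound 1 to compound 3 (0.35 log units; beyond the scatter), and the third gives a 2.4-fold lower number from compound 2 to compound 3 (0.38 log units; beyond the scatter). None of them tests 4-butoxyphenyl, so they offer only a loose guide. A small move towards a lower number is expected, with the estimated step being a 1.5-fold lower number from compound 1 to compound 4 (0.19 log units; within the scatter). For compound 4 the expected value is 7 ug/mL, with an estimated range of 3 ug/mL to 16 ug/mL.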

Compound 4, half-maximal inhibitory concentration: 12.9 ug/mL
Compound 4: the middle estimate sits 1.8-fold (0.27 log units) below what was measured, within the range that was stated.
By their numbers in this assay, from the lowest: compound 3; then compounds 1, 2 and 4 (each within the scatter of the next).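

In this assay the 4-butoxyphenyl group on the carbonyl carbon cannot be told apart from 3,4-dichlorophenyl, with a 1.2-fold higher number from compound 1 to compound 4 (0.08 log units; within the scatter), or from 3-methoxyphenyl, with a 1.1-fold higher number from compound 2 to compound 4 (0.05 log units; within the scatter). Butoxy in place of methyl on an aromatic carbon gives a 2.7-fold higher number from compound 3 to compound 4 (0.43 log units; beyond the scatter), so among these four compounds only compound 3 stands apart, with the lower number. Nothing available here accounts for this result. From the compounds shown here alone, it remains open whether ethoxy or an amine in place of butoxy would give a number like that of compound 3 or like those of the other three.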